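A few compounds are considered here, and "the series" means these few. Any claim that something is new, unique, unknown or untested is made for them only; others in the source may bear on it.

Measured so far:
compound 1 `COc1ccc(/C=C/C(=O)CC(=O)/C=C/c2ccc(O)c(OC)c2)cc1` — 79000 nM
compound 2 `COc1ccc(/C=C/C(=O)CC(=O)/C=C/c2ccc(O)cc2)cc1` — 400000 nM
compound 3 `COc1cc(/C=C/C(=O)CC(=O)/C=C/c2ccc(OC(C)=O)c(OC)c2)ccc1OC(C)=O` — 80000 nM

In an ADME assay on HEK293 cells (Homo sapiens) for cytotoxicity, read by resazurin assay, with a stated time of 16 h (a lower number here means that less compound is needed, a higher number that more compound is needed for the effect), compound 1 gives 79000 nM. Its neighbour compound 2 arose by hydrogen in place of methoxy on an aromatic carbon and this step, a 5.1-fold higher number from compound 1 to compound 2 (0.70 log units; beyond the scatter), went beyond the scatter. Compound 3 carries acetoxy groups where compound 1 carries a hydroxy group; the difference between the two cores is not broken down here. Compound 3 gives 80000 nM in this assay, within the scatter of compound 1. Compound 4 `COc1cc(/C=C/C(=O)CC(=O)/C=C/c2ccc(OC(C)=O)cc2)ccc1OC(C)=O` differs from compound 3 by hydrogen in place of methoxy on an aromatic carbon. This is the same kind of change as from compound 1 to compound 2, though there the methoxy sat ortho to a hydroxy group and here ortho to an acetoxy group. Because a 5.1-fold higher number from compound 1 to compound 2 (0.70 log units; beyond the scatter) shows a modest rise, a similar step is expected, a 3.8-fold higher number from compound 3 to compound 4 (0.57 log units; beyond the scatter). For compound 4 in this assay the estimate is 300000 nM, between 100000 nM and 800000 nM.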

Compound 4, half-maximal effective concentration: 49000 nM
Compound 4: the middle estimate sits 6.1-fold (0.79 log units) above what was measured, and the stated range ends above it.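

In this assay, replacing methoxy with hydrogen on the core of compound 3 gives a 1.6-fold lower number from compound 3 to compound 4 (0.21 log units; within the scatter), so the clear rise seen on the core of compound 1 does not carry over. Set side by side, the two steps differ by more than the usual scatter of repeated measurements: the same change on two cores in this assay, a 5.1-fold higher number (0.70 log units; beyond the scatter) from compound 1 to compound 2 and a 1.6-fold lower number (0.21 log units; within the scatter) from compound 3 to compound 4, 8.3-fold (0.92 log units) apart, beyond the scatter of two such steps

This shows that, in these compounds, the size of this change depends on the core, so a step measured on one core is a poor guide to the other; it does not show which difference between the cores is responsible.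

The compounds shown leave open how a fluorine atom or an amine would behave in that position. They also leave open what the same change would do on a core carrying a single acetoxy group.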